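A few compounds are considered here, and "the series" means these few. Any claim that something is new, unique, unknown or untested is made for them only; others in the source may bear on it.

Three compounds carry measured numbers in a functional assay on MCF7 cells (Homo sapiens) for antiproliferative activity, read by CCK-8 assay, with a stated time of 72 h; a lower number here means a stronger inhibitor of growth, a higher number a weaker inhibitor of growth. Compound 1 `CC[C@@H]1C(=O)N(C)c2cnc(Nc3ccc(S(=O)(=O)NC4CCCC4)cc3)nc2N1C1CCCC1` gives 688 nM. Compound 3 `CCCCNS(=O)(=O)c1ccc(Nc2ncc3c(n2)N(c2ccn(C)n2)C(CC)C(=O)N3C)cc1` gives 5780 nM. Compound 2 `CCC1C(=O)N(C)c2cnc(-n3ccc4cc(C(=O)NC)ccc43)nc2N1c1ccn(C)n1` gives 35400 nM, the highest of the three, with its gap to compound 3 and its larger gap to compound 1 both beyond the scatter. The piece follows the change from compound 2 to compound 4 `CCCNC(=O)c1ccc2c(ccn2-c2ncc3c(n2)N(c2ccn(C)n2)C(CC)C(=O)N3C)c1`, not yet measured in this assay. The change is ethyl in place of hydrogen on a saturated chain carbon bound to an amide-type nitrogen, read one bond further out as methylcarbamoyl to propylcarbamoyl. Within the data shown here, no measured pair in the set carries this change, so its size is open. The expected step is a 1.4-fold lower number from compound 2 to compound 4 (0.15 log units; within the scatter), small, toward a slightly lower number, and not clearly beyond the scatter. For compound 4 the estimate is 25000 nM, with a range from 8000 nM to 80000 nM.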

Compound 4, concentration for 50% growth inhibition: 6420 nM
Estimate against measurement, compound 4: 3.9-fold (0.59 log units) above, and the stated range ends above it.
By their numbers in this assay, from the lowest: compound 1; then compounds 3 and 4 (each within the scatter of the next); then compound 2.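

Methylcarbamoyl to propylcarbamoyl gives the first single-place change in the series: in this assay it brings a 5.5-fold lower number from compound 2 to compound 4 (0.74 log units; beyond the scatter), so this position on the saturated chain carbon bound to an amide-type nitrogen is not silent to added ethyl. This rests on one pair and one direction. Nothing available bears on the reason for the step.

Going by these compounds, whether a longer chain such as butyl or pentyl extends the step remains open. So does the effect of a terminal amine or carboxylic acid on the propyl chain.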